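A few compounds are considered here, and "the series" means these few. Any claim that something is new, unique, unknown or untested is made for them only; others in the source may bear on it.

In a functional assay on MCF7 cells (Homo sapiens) for cytotoxicity, read by MTT assay, with a stated time of 48 h (on this read-out higher numbers stand for weaker inhibition and lower numbers for stronger inhibition), compound 1 `O=C(Nc1ccc(Cl)cc1)c1cn(-c2ccccc2)nc1-c1ccccc1` gives 3860 nM, compound 2 `COc1ccc(NC(=O)c2cn(-c3ccccc3)nc2-c2ccccc2)cc1` gives 1710 nM, and compound 3 `CCOc1ccc(NC(=O)c2cn(-c3ccccc3)nc2-c2ccccc2)cc1` gives 880 nM. Compound 2 thus stands second highest of the three numbers: the nearest step is a 1.9-fold lower number from compound 2 to compound 3 (0.29 log units; within the scatter), the further one a 2.3-fold lower number from compound 1 to compound 2 (0.35 log units; beyond the scatter). Compound 4 `COc1ccc(NC(=O)c2cn(-c3ccccc3)nc2-c2ccc(Cl)cc2)cc1` differs from compound 2 by chloro in place of hydrogen on an aromatic carbon, where the same difference cut one bond further out reads phenyl to 4-chlorophenyl. For the measured compounds named here, none of the measured steps touches that ring. The steps of a 2.3-fold lower number from compound 1 to compound 2 (0.35 log units; beyond the scatter), a 4.4-fold lower number from compound 1 to compound 3 (0.64 log units; beyond the scatter) and a 1.9-fold lower number from compound 2 to compound 3 (0.29 log units; within the scatter) all concern the ring bearing the amide nitrogen, and each was modest or within the scatter. There is no direct guide for the new position, and the whole series moves only modestly. For compound 4 in this assay the estimated step is a 1.1-fold lower number from compound 2 to compound 4 (0.06 log units; within the scatter), which is expected to lie within the scatter. The estimate for compound 4 is 1500 nM, in a range from 600 nM to 4000 nM.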

Compound 4, half-maximal inhibitory concentration: 1550 nM
The estimate for compound 4 lay 1.0-fold (0.01 log units) below the measured number, and the stated range covers the measured number.
By their numbers in this assay, from the lowest: compounds 3, 4 and 2 (each within the scatter of the next); then compound 1.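

In this assay, replacing phenyl with 4-chlorophenyl gives a 1.1-fold lower number from compound 2 to compound 4 (0.04 log units; within the scatter). For the compounds shown here, this is the first information about this ring, since the earlier steps all concerned the ring bearing the amide nitrogen, and it shows that a chloro on an aromatic carbon para to a large group leaves the number within the scatter when the methoxy group of compound 2 is present. No evidence is available that bears on this result.

As far as these compounds go, it remains open whether a different group at this place, such as an amine, a carboxylic acid or a longer chain, would move the number beyond the scatter. From the compounds shown here alone, it is equally open whether the same chloro would leave the number of compound 3, with its ethoxy group, within the scatter.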